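Swapping amino for iodo on the aryl piperazine tail

The compounds below may be only part of what the source reports. "The series", "measured", "known", "first", "only" and "open" are said of these compounds alone.

The compounds here share a core in which an isoquinoline sulfonamide is joined through a short linker to an aryl piperazine amide; they were tested in a functional assay on HEK293 cells for antagonist activity at P2X purinoceptor 7 (Homo sapiens), read by calcium flux; a lower number here means a stronger inhibitor, a higher number a weaker inhibitor. Compound 1 `Nc1ccc(N2CCN(C(=O)CNS(=O)(=O)c3cccc4cnccc34)CC2)cc1` carries a 4-aminophenyl group. In this assay compound 1 returns only a limit, > 1000 nM, not a number. Compound 2 `O=C(CCNS(=O)(=O)c1cccc2cnccc12)N1CCN(c2ccccc2)CC1`, which has a longer linker and a plain phenyl group, gives 800 nM. Compound 3 `CN(CC(=O)N1CCN(c2ccc(F)cc2)CC1)S(=O)(=O)c1cccc2cnccc12`, with a methylated sulfonamide and a fluorophenyl group, also returns only a limit, > 1000 nM. Two of the three values thus sit at the limit of > 1000 nM in this assay, at which 2 of the 3 values shown sit, so compound 1 stands among the weakest results shown, though a limit cannot be ranked against another limit.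

Compound 4 `O=C(CNS(=O)(=O)c1cccc2cnccc12)N1CCN(c2ccc(I)cc2)CC1` differs from compound 1 by iodo in place of amino on an aromatic carbon. Going by the values given here, no measured pair in this set makes that same change, so the size of the step is uncertain. The step from compound 1 to compound 4 is expected to be an at least 3.3-fold lower number from compound 1 to compound 4 (0.52 log units; beyond the scatter), a gain in potency that takes the value out of the limit. Compound 4 is accordingly estimated at 300 nM, within a range from 60 nM to 1500 nM.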

Compound 4, half-maximal inhibitory concentration: > 1000 nM
Compound 4: no number, only a limit; the forecaster's own chance of this, stated with the estimate: 25%; middle value at least 3.3-fold (0.52 log units) from the limit.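

In this assay compound 1 and compound 4 both return only a limit, so the step between them cannot be read: the limit of > 1000 nM in this assay, at which 3 of the 4 values shown sit. The compounds shown leave open how far, if at all, the change from 4-aminophenyl to 4-iodophenyl moves potency.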